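Swapping the aryl group on the ring amine nitrogen

The compounds below may be only part of what the source reports. "The series", "measured", "known", "first", "only" and "open" are said of these compounds alone.

Compound 1 `Nc1scc(CN2CCN(c3ccc([N+](=O)[O-])cc3)CC2)c1C(=O)c1ccc(Cl)cc1` and compound 2 `Nc1scc(CN2CCN(c3ccc(OC(F)(F)F)cc3)CC2)c1C(=O)c1ccc(Cl)cc1` share one core and differ only in the group on the aromatic ring at the far end. In a functional assay on CHO cells with adenosine receptor A1 (Homo sapiens) as the target, read by cAMP accumulation and immunoassay, with a stated time of 6 min, tested at 0.1 uM (on this read-out higher numbers stand for a weaker effect at the one concentration tested and lower numbers for a stronger effect), compound 1 gives -13%, and in this assay compound 2 gives -13%. For the measured compounds named here, the only measured step, no change at the digits printed from compound 1 to compound 2 (within the scatter), shows that exchanging these two groups left the read-out where it was, so compound 2 stands level with compound 1.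

Compound 3 `Nc1scc(CN2CCN(c3cccc(F)c3)CC2)c1C(=O)c1ccc(Cl)cc1` has not yet been measured. It differs from compound 2 in a single place: 3-fluorophenyl in place of 4-(trifluoromethoxy)phenyl on an amine nitrogen in a ring. Going by the values given here, the one measured step bears on this change only loosely, since it touched a different group on the same aromatic ring and moved nothing beyond the scatter. Among the compounds with values here, with no step of real size to point in either direction, the expectation for compound 3 is that the step of a number 3 percentage points higher from compound 2 to compound 3 (within the scatter) stays within the scatter, without a clear direction. Compound 3 is therefore estimated to give -10% in this assay, with a range from -30% to 15%.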

Compound 3, a percentage reported as activity, at one concentration (the size of the read-out at that concentration, not a potency): -37%
Compound 3: the middle estimate sits 27 percentage points above what was measured; measured number outside the range, below it.
By their numbers in this assay, from the lowest: compound 3; then compounds 1 and 2 (each within the scatter of the next).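

In this assay, the aryl group on the ring amine nitrogen can move the read-out after all: the change to 3-fluorophenyl gives a number 24 percentage points lower from compound 2 to compound 3 (beyond the scatter) and also a number 24 percentage points lower from compound 1 to compound 3 (beyond the scatter) in the direction of a stronger effect at the one concentration tested. The position is therefore not indifferent to what it carries, even though 4-nitrophenyl and 4-(trifluoromethoxy)phenyl left compound 1 and compound 2 level, and this is a difference in the size of the read-out at one concentration rather than a difference in potency. No measurement shown here explains why the 3-fluorophenyl compound separates from the other two.

The step to compound 3 changes both the identity of the substituent and where it sits on the aromatic ring, so these compounds cannot show which of the two matters. From the compounds shown here alone, it also remains open whether a plain phenyl group, a 3-chlorophenyl group or a 3-methoxyphenyl group would read like compound 3 or like compound 1 and compound 2, and whether the shift would hold at other concentrations.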